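This account rests on a few compounds, and the source may have more. Where it says the series, first, only, none or still open, it means among the compounds named here.

Measured compounds:
compound 1, `CCc1cccc2c(OC)c(-c3occ(C)c3C(=O)OC)ccc12`: 1.3 ug/mL
compound 2, `CCOc1c(-c2occ(C)c2C(=O)OC)ccc2c(CC)cccc12`: 1.2 ug/mL

In a functional assay on ZR-75-1 cells (Homo sapiens) for cytotoxicity, read by MTT assay, with a stated time of 72 h (a higher number here means that more compound is needed for the effect, a lower number that less compound is needed), compound 2 stands beside compound 1, the two values lying within the scatter of each other; the step of a 1.1-fold lower number from compound 1 to compound 2 (0.03 log units; within the scatter) is methyl in place of hydrogen on a saturated chain carbon bound to an oxygen on an aromatic ring. Compound 3, `CCOc1c(-c2occ(C)c2COC)ccc2c(CC)cccc12`, differs from compound 2 by methoxymethyl in place of methoxycarbonyl on an aromatic carbon. Going by the values given here, no measured step touches this five-membered ring, so nothing recorded bears on the change, and no step beyond the scatter can be argued for in either direction. Compound 3 is therefore expected to give about 1.5 ug/mL, between 0.6 ug/mL and 4 ug/mL, an expected step of a 1.3-fold higher number from compound 2 to compound 3 (0.10 log units; within the scatter).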

Compound 3, concentration for half-maximal effect: > 10 ug/mL
Compound 3: a limit, no number (the forecaster's own chance of this, stated with the estimate: 5%); middle value at least 6.6-fold (0.82 log units) from the limit.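

In this assay compound 3 gives > 10 ug/mL, which is a limit of the assay and not a number. Methoxymethyl in place of methoxycarbonyl on this carbon of the five-membered ring gives an at least 8.3-fold higher number from compound 2 to compound 3 (0.92 log units; beyond the scatter), so the group at this position matters for the read-out, whereas the earlier step on the chain at the oxygen stayed within the scatter. The compounds shown do not say which part of the methoxycarbonyl group counts. As far as these compounds go, what a carboxylic acid, an amide or a hydroxymethyl group would give on this carbon stays open, as does the true value of compound 3.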